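A Smaller Group on the Shared Core

The source may hold more compounds than are shown below. What is called first, only, known or untested is meant among the compounds shown, and "the series" means these compounds.

Measured so far in a functional assay on SW-620 cells (Homo sapiens) for antiproliferative activity, read by MTT assay, with a stated time of 72 h; a lower number here means a stronger inhibitor, a higher number a weaker inhibitor:
compound 1 `Cc1ccc(S(=O)(=O)NCc2cn(C[C@H](O)[C@H]3OC(=O)C(OCc4ccccc4)=C3OCc3ccccc3)nn2)cc1`: 45800 nM
compound 2 `O=C1O[C@H]([C@@H](O)Cn2cc(CNS(=O)(=O)c3ccc(Cl)cc3F)nn2)C(OCc2ccccc2)=C1OCc1ccccc1`: 42400 nM
compound 3 `CC(C)(C)OC(=O)N1CCN(C(=S)SCc2cn(C[C@H](O)[C@H]3OC(=O)C(OCc4ccccc4)=C3OCc3ccccc3)nn2)CC1`: > 100000 nM, which is a limit of the assay and not a number.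

Of the two numbers, compound 1 stands highest, and its nearest neighbour is compound 2, with a 1.1-fold lower number from compound 1 to compound 2 (0.03 log units; within the scatter). Compound 4 `O=C1O[C@H]([C@@H](O)Cn2cc(C3CC3)nn2)C(OCc2ccccc2)=C1OCc1ccccc1` differs from compound 1 by cyclopropyl in place of (((4-methylphenyl)sulfonyl)amino)methyl on an aromatic carbon. Among the compounds with values here, the only measured step, from compound 1 to compound 2, changes just the aryl group on the sulfonyl sulfur and stays within the scatter; no measured step removes the whole sulfonamide arm or brings in a small ring, so none bears directly on this change. The expected step is therefore a 1.3-fold higher number from compound 1 to compound 4 (0.12 log units; within the scatter), within the scatter. The estimate for compound 4 is 60000 nM, between 25000 nM and 150000 nM.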

Compound 4, half-maximal inhibitory concentration: 54200 nM
For compound 4 the middle estimate is 1.1-fold (0.04 log units) above the measured one; measured number inside the range.
By their numbers in this assay, from the lowest: compounds 2, 1 and 4 (each within the scatter of the next). At a limit, above all of these: compound 3.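

In this assay, replacing the whole (((4-methylphenyl)sulfonyl)amino)methyl arm with cyclopropyl gives a 1.2-fold higher number from compound 1 to compound 4 (0.07 log units; within the scatter). The earlier step changed only the aryl group and kept the arm, whereas this one shows that the position on the aromatic carbon can carry a much smaller group, without a hydrogen-bond donor or acceptor, and the number stays within the scatter. Nothing measured here gives a reason for this result. Going by these compounds, whether an amine, a carboxylic acid or a longer alkyl chain at this position would shift the number remains open. So does whether any group here can bring it clearly lower.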